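Methyl to chloro step in the diethylaminopropyl series

The compounds below may be only part of what the source reports. "The series", "measured", "known", "first", "only" and "open" are said of these compounds alone.

Values in a functional assay on K562 cells (Homo sapiens) for cytotoxicity, read by sulforhodamine B assay, with a stated time of 48 h; a lower number here means a stronger inhibitor, a higher number a weaker inhibitor:
- compound 1 `CCN(CC)CCCn1c(=O)/c(=C/c2cc(OC)c(OC)c(OC)c2)s/c1=C1/C(=O)Nc2ccc(C)cc21` gives 4170 nM
- compound 2 `CCN(CC)CCCn1c(=O)/c(=C/c2ccccc2O)s/c1=C1\C(=O)Nc2ccc(C)cc21` gives 14800 nM
- compound 3 `CCN(CC)CCCn1c(=O)/c(=C/c2cc(OC)c(OC)c(OC)c2)s/c1=C1\C(=O)Nc2ccc(Cl)cc21` gives 820 nM

Compound 1 at 4170 nM is second highest of the three numbers, with compound 2 higher and compound 3 lower, both gaps beyond the scatter. Compound 4 `CCN(CC)CCCn1c(=O)/c(=C/c2cc(OC)c(OC)c(OC)c2)s/c1=C1/C(=O)Nc2ccc(Cl)cc21` has chloro in place of methyl on an aromatic carbon and is otherwise drawn like compound 1. Among the compounds with values here, no measured pair shows this change alone. Compound 3, which also carries chloro, gives 820 nM and so points to a lower number. A moderate drop in this assay is therefore expected, with the estimated move being a 2.8-fold lower number from compound 1 to compound 4 (0.44 log units; beyond the scatter) in size. For compound 4 the expected value is 1500 nM within an estimated range of 500 nM to 4200 nM here.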

Compound 4, half-maximal inhibitory concentration: 820 nM
The estimate for compound 4 lay 1.8-fold (0.26 log units) above the measured number, and the stated range covers the measured number.
By their numbers in this assay, from the lowest: compounds 3 and 4 (each within the scatter of the next); then compound 1; then compound 2.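

In this assay, chloro in place of methyl on an aromatic carbon now has a single-change reading at this position: a 5.1-fold lower number from compound 1 to compound 4 (0.71 log units; beyond the scatter). Between the two chloro compounds, the double-bond configuration as drawn carries no visible weight, with no change at the digits printed from compound 3 to compound 4 (within the scatter). This second reading comes from a pair matched in all but the drawing: the fact that compounds 3 and 4 differ only in the configuration as drawn

Still open, going by these compounds, is how a fluoro, a nitrile or an amine would compare with chloro and methyl at this position. Also open, on these data alone, is whether the methyl to chloro step carries over to the aryl group of compound 2.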